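Swapping a ring beside the sulfonyl on two related cores

This account rests on a few compounds, and the source may have more. Where it says the series, first, only, none or still open, it means among the compounds named here.

Measured so far:
compound 1, `COc1ccc(C2=NN(c3ccccc3)C(c3ccc(C)cc3)C2S(=O)(=O)CC2=NCCO2)cc1`, 64.9%
compound 2, `COc1ccc(-c2nn(-c3ccccc3)c(-c3ccc(C)cc3)c2S(=O)(=O)CC2=NCCS2)cc1`, "not active" (no number reported)
compound 3, `COc1ccc(C2=NN(c3ccccc3)C(c3ccc(C)cc3)C2S(=O)(=O)CC2=NCCS2)cc1`, 44.9%

All three were tested in a functional assay, read by Griess assay, with a stated time of 150 min, tested at 75 ug/mL; on this read-out lower numbers stand for a weaker effect and higher numbers for a stronger effect at the one concentration tested. Compound 1 gives 64.9% and compound 3 gives 44.9%. Compound 2 comes out as "not active" (no number reported), so no single number stands for it. The cores of compound 2 and compound 3 are not the same; how they differ is not broken down here.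

Compound 1 and compound 3 share one core and differ only in a group of 5 heavy atoms (3 carbon, 1 nitrogen, 1 oxygen; one five-membered non-aromatic ring with 2 hetero atoms) in place of a group of 5 heavy atoms (3 carbon, 1 nitrogen, 1 sulfur; one five-membered non-aromatic ring with 2 hetero atoms), on a saturated chain carbon bound to a sulfonyl sulfur. That change gave a number 20 percentage points higher from compound 3 to compound 1 (beyond the scatter). The unmeasured compound 4, `COc1ccc(-c2nn(-c3ccccc3)c(-c3ccc(C)cc3)c2S(=O)(=O)CC2=NCCO2)cc1`, carries the same change on the core of compound 2: a group of 5 heavy atoms (3 carbon, 1 nitrogen, 1 oxygen; one five-membered non-aromatic ring with 2 hetero atoms) in place of a group of 5 heavy atoms (3 carbon, 1 nitrogen, 1 sulfur; one five-membered non-aromatic ring with 2 hetero atoms), on a saturated chain carbon bound to a sulfonyl sulfur. The place is the same in both pairs, so it is the same change, only on a different core.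

Among the measured compounds shown here, because the one measured step, a number 20 percentage points higher from compound 3 to compound 1 (beyond the scatter), was modest and compound 2 gave "not active" (no number reported), only a small rise is expected for compound 4 in this assay. Compound 4 is estimated at 20%, likely between 0% and 45%.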

Compound 4, a percentage reported as activity, at one concentration (the size of the read-out at that concentration, not a potency): 66.6%
Beside the measured number, compound 4's estimate is 46.6 percentage points below it; measured number outside the range, above it.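

Among the compounds shown here, compound 2 carries no number, only the words "not active", so no step from compound 2 to compound 4 can be read. The compounds shown leave open how large the ring change is on this core. No supporting data here offer an explanation for the result.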